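From a Sulfo Limit to an Unsaturated Ester

The source may report more compounds than this note shows. Statements on the series, on what has been measured and on what is new or still open speak of the compounds shown alone.

In a functional assay on CLL cells (Homo sapiens) for cytotoxicity, read by MTT assay, with a stated time of 48 h (on this read-out higher numbers stand for an effect only at larger amounts of compound and lower numbers for an effect already at smaller amounts), compound 1 (`C=C(CC)C(=O)c1ccc(OCC(=O)Nc2ccc(C(=O)O)cn2)c(Cl)c1Cl`) gives 14900 nM and compound 2 (`C=C(CC)C(=O)c1ccc(OCC(=O)Nc2ccc(O)c([N+](=O)[O-])c2)c(Cl)c1Cl`) gives 7400 nM on the same read-out. Compound 3 (`C=C(CC)C(=O)c1ccc(OCC(=O)Nc2ccc(S(=O)(=O)O)cc2)c(Cl)c1Cl`) reads > 25000 nM in this assay as a limit of the assay and not a number. Its place on the scale is therefore known only through that limit, and no comparison of a single change exists among these three compounds.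

Compound 4 (`C=C(CC)C(=O)c1ccc(OCC(=O)Nc2ccc(/C=C/C(=O)OCC)cc2)c(Cl)c1Cl`) keeps the core of compound 3 and alters one group, with 2-(ethoxycarbonyl)ethenyl in place of sulfo on an aromatic carbon. The change sits para to a large group.

Within the data shown here, the only guide comes from the two measured neighbours. Neither compound 2, which reads 7400 nM here, nor compound 1, which reads 14900 nM here, carries the sulfo group, and both return numbers rather than a limit. A step of an at least 3.5-fold lower number from compound 3 to compound 4 (0.55 log units; beyond the scatter) toward lower numbers is therefore expected in this assay and would lie beyond the usual scatter. The starting point of that expected step is only a limit. Compound 4 is estimated at 7000 nM in this assay with an expected range from 2500 nM to 20000 nM on this read-out.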

Compound 4, half-maximal effective concentration: 1700 nM
Compound 4: middle estimate off by 4.1-fold (0.61 log units), on the high side, and the stated range ends above it.
By their numbers in this assay, from the lowest: compound 4; then compounds 2 and 1 (each within the scatter of the next). At a limit, above all of these: compound 3.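

In this assay, among these compounds, replacing sulfo with 2-(ethoxycarbonyl)ethenyl on the aromatic carbon para to a large group gives an at least 14-fold lower number from compound 3 to compound 4 (1.16 log units; beyond the scatter), the first comparison in this set that isolates one change. Among the compounds shown here, it shows that the group on this carbon can shift the read-out beyond the usual scatter, which the earlier compounds could not show, as they offered no comparison of a single change. Compound 3 stands at a limit of the assay and not at a number, so the printed step gives only the smallest size the change can have, and its true size remains unknown: the limit of > 25000 nM in this assay, at which 1 of the 4 values shown sits.

The compounds shown do not separate the departure of sulfo from any contribution of the entering chain, which differs in its atoms, its count of hydrogen-bond donors and its length all at once. Still open, from the compounds shown here alone, is how the read-out would respond on this same carbon to a carboxylic acid in place of the ethyl ester, to a saturated ethyl propanoate chain without the double bond, or to a simple amine.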